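The source may report more compounds than this note shows. Statements on the series, on what has been measured and on what is new or still open speak of the compounds shown alone.

Compound 1 `CCCSc1nc(N/N=C/c2ccc(Cl)cc2)c2nnn(Cc3ccccc3)c2n1`: > 64000 nM
Compound 2 `CCCSc1nc(N/N=C/c2ccc3ccccc3c2)c2nnn(Cc3ccccc3)c2n1`: > 64000 nM
Compound 3 `CCCSc1nc(N/N=C/c2c[nH]c3ccccc23)c2nnn(Cc3ccccc3)c2n1`: 9010 nM

All three were tested in a functional assay on MCF7 cells (Homo sapiens) for antiproliferative activity, read by MTT assay, with a stated time of 72 h; on this read-out higher numbers stand for weaker inhibition and lower numbers for stronger inhibition. For compound 1 the value > 64000 nM is a limit of the assay and not a number. For compound 2 the value > 64000 nM is likewise a limit. Among the measured compounds shown here, compound 3 gives 9010 nM, the only full number among the three, so the set is shaped by the limit of > 64000 nM in this assay, at which 2 of the 3 values shown sit.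

Compound 4 `CCCSc1nc(N/N=C(\C)c2ccccc2O)c2nnn(Cc3ccccc3)c2n1` has not been measured. It differs from compound 1 by a group of 10 heavy atoms (8 carbon, 1 nitrogen, 1 oxygen; one six-membered aromatic ring of carbon only) in place of a group of 9 heavy atoms (7 carbon, 1 nitrogen, 1 chlorine; one six-membered aromatic ring of carbon only), on a nitrogen on an aromatic ring. Two measured steps change the same part of the core: a step that the two limits leave unreadable from compound 1 to compound 2 and an at least 7.1-fold lower number from compound 1 to compound 3 (0.85 log units; beyond the scatter). Neither of these brings in the hydroxyl group or the methyl group that enter here, so they are only loose guides; they show that a plain aromatic ring in this position can leave the number at the limit, while an indole ring pulls it down. For compound 4 the expectation is a number near the limit of compound 1, that is an at least 1.2-fold lower number from compound 1 to compound 4 (0.10 log units; that floor lies within the scatter), with an estimate of 50000 nM in the range 10000 nM to 200000 nM.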

Compound 4, half-maximal inhibitory concentration: 11000 nM
Estimate against measurement, compound 4: 4.5-fold (0.66 log units) above, and the stated range covers the measured number.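

In this assay, the change on a nitrogen on an aromatic ring gives an at least 5.8-fold lower number from compound 1 to compound 4 (0.76 log units; beyond the scatter), so a six-membered ring of carbon only can also leave the limit once the entering group brings a hydroxyl group and a methyl group. Among the compounds shown here, an indole ring is therefore not the only group here with a full number: compound 3 gives 9010 nM and compound 4 gives 11000 nM. Compound 1 stands at > 64000 nM, which is a limit of the assay and not a number, so the step is only a floor: the limit of > 64000 nM in this assay, at which 2 of the 4 values shown sit.

The hydroxyl group and the methyl group enter together, so the compounds shown do not tell which of them goes with the step. From the compounds shown here alone, how an amine or a methoxy group in place of the hydroxyl group, or an ethyl group in place of the methyl group, would read also stays open.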